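Compound 4 and the phenyl swap on compound 1

The source may report more compounds than this note shows. Statements on the series, on what has been measured and on what is new or still open speak of the compounds shown alone.

Values in a physicochemical assay for solubility, measured as kinetic solubility, at pH 2 (a lower number here means a less soluble compound, a higher number a more soluble compound), so far
- compound 1 `CCC(CC)C(/C=C1\OC(=O)NC1=O)c1ccc(-c2ccc3cccc(F)c3c2)[nH]c1=O` gives 3680 nM
- compound 2 `CC(C)C(c1ccc(-c2ccc3cccc(F)c3c2)[nH]c1=O)C1SC(=O)NC1=O` gives 11300 nM
- compound 3 `O=C1NC(=O)/C(=C/C2(c3ccc(-c4ccc5cccc(F)c5c4)[nH]c3=O)CC2)O1` gives 27400 nM

Compound 1 (3680 nM) stands lowest of the three. Compound 2 (11300 nM) and compound 3 (27400 nM) both lie above it, beyond the scatter.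

The next compound to be read is compound 4 `O=C1NC(=O)/C(=C/C(c2ccccc2)c2ccc(-c3ccc4cccc(F)c4c3)[nH]c2=O)O1`, which has phenyl in place of pentan-3-yl on a saturated chain carbon bound to an aromatic carbon and a double-bonded chain carbon. Within the data shown here, no two measured compounds differ in one place, so the series offers no direct precedent for this change, and any expectation is loose.

Compound 1 at 3680 nM sits at the bottom of the measured values, which leaves more room above it than below, so a small rise is the slightly likelier direction. A step beyond the scatter in this assay is not expected. The estimated step of a 1.5-fold higher number from compound 1 to compound 4 (0.17 log units; within the scatter) is expected to stay within the scatter. For compound 4 the expected value is 5500 nM with 1800 nM to 17000 nM as the estimated range.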

Compound 4, solubility: 15400 nM
The estimate for compound 4 lay 2.8-fold (0.45 log units) below the measured number; measured number inside the range.
By their numbers in this assay, from the lowest: compound 1; then compounds 2, 4 and 3 (each within the scatter of the next, the first and the last beyond it).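

In this assay, among these compounds, phenyl in place of pentan-3-yl on a saturated chain carbon bound to an aromatic carbon and a double-bonded chain carbon gives a 4.2-fold higher number from compound 1 to compound 4 (0.62 log units; beyond the scatter) and provides the first step that can be read at a single place. The group on this carbon can therefore move the number beyond the scatter with the rest of compound 1 unchanged, even though neither group carries a hydrogen-bond donor or acceptor. No measurement at hand bears on the reason for this step, so it stands as an observation on one pair.

This single pair leaves open whether a saturated ring such as cyclohexyl, or a nitrogen-containing ring such as pyridyl, on the same carbon would read closer to phenyl or to pentan-3-yl. It also leaves open whether the same swap would give a similar step in the setting of compound 2, which differs from compound 1 in more than one place.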